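The source may report more compounds than this note shows. Statements on the series, on what has been measured and on what is new or still open speak of the compounds shown alone.

Values in a functional assay on NCI-H520 cells (Homo sapiens) (on this read-out higher numbers stand for weaker inhibition of growth and lower numbers for stronger inhibition of growth), so far
- compound 1 `O=S(=O)(/C=C/c1ccc(Cl)cc1)Cc1ccc(Nc2ncnc3ccccc23)cc1` gives 46000 nM
- compound 2 `O=S(=O)(/C=C/c1ccc(Cl)cc1Cl)Cc1ccc(Nc2ncnc3ccccc23)cc1` gives 12000 nM
- compound 3 `O=S(=O)(/C=C/c1ccc(Cl)cc1)Cc1ccc(Nc2ncnc3ccc(Br)cc23)cc1` gives 13000 nM

The values of compound 2 and compound 3 lie within the scatter of each other, and both sit lower than compound 1 by steps beyond the scatter. Next in line is compound 4 `O=S(=O)(/C=C/c1ccc(F)cc1F)Cc1ccc(Nc2ncnc3ccc(Br)cc23)cc1` which keeps the bromo of compound 3. The change from compound 3 to compound 4 is 2,4-difluorophenyl in place of 4-chlorophenyl on a double-bonded chain carbon bound to a double-bonded chain carbon with 2,4-difluorophenyl in place of 4-chlorophenyl on a double-bonded chain carbon bound to a double-bonded chain carbon.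

The nearest measured step touches the same phenyl group: a 3.8-fold lower number from compound 1 to compound 2 (0.58 log units; beyond the scatter) with chloro in place of hydrogen on an aromatic carbon, modest in size. The other step, a 3.5-fold lower number from compound 1 to compound 3 (0.55 log units; beyond the scatter) with bromo in place of hydrogen on an aromatic carbon, is also modest, but that bromo stays in place here, so it bears only on the starting level. For the measured compounds named here, no fluoro compound has been measured, so the first step transfers only loosely. In this assay a slight lowering is therefore expected, not beyond the scatter. The expected move is a 1.6-fold lower number from compound 3 to compound 4 (0.21 log units; within the scatter) as estimated here. For compound 4 the estimated value is 8000 nM with an expected range from 2500 nM to 25000 nM for now.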

Compound 4, concentration for 50% growth inhibition: 100000 nM
Compound 4: the middle estimate sits 13-fold (1.10 log units) below what was measured, outside the stated range (above it).
By their numbers in this assay, from the lowest: compounds 2 and 3 (each within the scatter of the next); then compound 1; then compound 4.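

In this assay, for the compounds shown here, the exchange of 4-chlorophenyl for 2,4-difluorophenyl brings a 7.7-fold higher number from compound 3 to compound 4 (0.89 log units; beyond the scatter) with the bromo held constant, and this is the only upward step so far. The position on the double-bonded chain carbon is therefore sensitive to which halogens the phenyl group carries, and adding halogen there does not lower the number as a general rule: a 3.8-fold lower number from compound 1 to compound 2 (0.58 log units; beyond the scatter) came with an added chloro, while compound 4, with its two fluorines, goes against that direction, although on a core that carries the bromo. Nothing at hand explains the rise, so the step stands as an observation without a cause.

The compounds shown leave open whether the rise follows from losing the chlorine or from gaining the fluorines, and whether the same exchange would act alike on the core without the bromo. Also open, from the compounds shown here alone, is how this phenyl group behaves with other substituents, such as a single fluoro, a methoxy, a dimethylamino group or a carboxylic acid.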